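Swapping the Sulfonyl Aryl Group of Compound 1

A few compounds are considered here, and "the series" means these few. Any claim that something is new, unique, unknown or untested is made for them only; others in the source may bear on it.

Three compounds have so far been measured in an assay on cells for inhibition of HSP60/HSP10 (Homo sapiens), with a stated time of 60 min; a higher number here means a weaker inhibitor, a lower number a stronger inhibitor:
compound 1 `O=S(=O)(Nc1ccc2oc(-c3ccccc3)nc2c1)c1ccccc1O` gives 85000 nM
compound 2 `O=S(=O)(Nc1ccc(-c2nc3cc(NS(=O)(=O)c4ccccc4O)ccc3o2)cc1)c1ccccc1O` gives 18000 nM
compound 3 `O=S(=O)(Nc1ccc(-c2nc3ccccc3o2)cc1)c1ccc(C(F)(F)F)cc1` gives 50000 nM

Compound 1 stands highest of these three numbers. Compound 3 lies nearest, and the two values sit within the scatter of each other, so nothing can be read between them. Compound 2 lies furthest: a 4.7-fold lower number from compound 1 to compound 2 (0.67 log units; beyond the scatter), brought about by ((2-hydroxyphenyl)sulfonyl)amino in place of hydrogen on an aromatic carbon.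

Compound 4 `C=Cc1ccc(S(=O)(=O)Nc2ccc3oc(-c4ccccc4)nc3c2)cc1` has not yet been measured. Going by the values given here, it differs from compound 1 in one place: 4-vinylphenyl in place of 2-hydroxyphenyl on a sulfonyl sulfur No measured step touches the sulfonyl sulfur; the one measured step alters a different position. Compound 3 carries another group on its sulfonyl sulfur but differs from compound 1 in more than one place, and its value and that of compound 1 lie within the scatter. One would therefore expect no step beyond the scatter, with a 1.2-fold lower number from compound 1 to compound 4 (0.08 log units; within the scatter) as the expected change. Compound 4 is estimated at 70000 nM, ranging from 25000 nM to 200000 nM.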

Compound 4, half-maximal inhibitory concentration: > 100000 nM
Compound 4 was reported as a limit (the forecaster's own chance of this, stated with the estimate: 25%); middle value at least 1.4-fold (0.15 log units) from the limit.
By their numbers in this assay, from the lowest: compound 2; then compounds 3 and 1 (each within the scatter of the next). At a limit, above all of these: compound 4.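

In this assay compound 4 gives > 100000 nM, which is a limit of the assay and not a number. Going by these compounds alone, putting 4-vinylphenyl in place of 2-hydroxyphenyl on the sulfonyl sulfur, the only measured change at this position on the core of compound 1, gives an at least 1.1-fold higher number from compound 1 to compound 4 (0.07 log units; that floor lies within the scatter). As far as these compounds go, the size of this step therefore stays unknown, yet the change brought no lower number. The swap removes the hydroxyl and adds the vinyl group together, so neither can be judged alone. From the compounds shown here alone, whether an amine or a carboxylic acid on this phenyl ring would give a lower number stays open.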